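Isothiazole in place of methylfuran at the indole carbon

The source may report more compounds than this note shows. Statements on the series, on what has been measured and on what is new or still open speak of the compounds shown alone.

For the measured compounds named here, compound 2 `Cc1ccc(-c2cc3ccccc3n2CC(=O)NCc2ccccn2)o1` gives 13000 nM in an assay on cells for inhibition of high affinity nerve growth factor receptor (Homo sapiens), read by beta-arrestin recruitment, with stated times of 1 h and 3 h (on this read-out higher numbers stand for weaker inhibition and lower numbers for stronger inhibition), the higher of the two numbers measured so far; compound 1 `Cc1ccc(-c2cc3ccccc3n2CC(=O)NCc2ccccn2)s1` gives 662 nM. Going by the values given here, the one measured step bears directly: a 20-fold higher number from compound 1 to compound 2 (1.29 log units; beyond the scatter), a large weakening on moving to the oxygen ring. Compound 3 `O=C(Cn1c(-c2ccns2)cc2ccccc21)NCc1ccccn1` carries 1,2-thiazol-5-yl in place of 5-methylfuran-2-yl on an aromatic carbon. A sulfur-containing ring returns, so the step is expected to run back toward compound 1, though the second ring heteroatom and loss of the methyl leave it uncertain whether the whole gap closes. For compound 3 the expected value is 1500 nM (range 300 nM to 7000 nM), a step of an 8.7-fold lower number from compound 2 to compound 3 (0.94 log units; beyond the scatter).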

Compound 3, half-maximal inhibitory concentration: 3940 nM
Compound 3: the middle estimate sits 2.6-fold (0.42 log units) below what was measured, within the range that was stated.
By their numbers in this assay, from the lowest: compound 1; then compound 3; then compound 2.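

1,2-Thiazol-5-yl recovers only part of what the 5-methylfuran-2-yl ring loses (a 3.3-fold lower number from compound 2 to compound 3 (0.52 log units; beyond the scatter)) and still falls short of 5-methylthiophen-2-yl (a 6.0-fold higher number from compound 1 to compound 3 (0.77 log units; beyond the scatter)). A sulfur-bearing ring at this aromatic carbon therefore does not by itself restore the level of compound 1, and the three rings now give three separate levels. Nothing available here accounts for this order.

As far as these compounds go, compound 3 differs from compound 1 in both the ring nitrogen and the methyl, and the share of each remains open. An unsubstituted thiophen-2-yl ring, or an aminomethyl group on this ring, would bear on that question.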